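Hydroxy Added to a Poorly Soluble Core

A few compounds are considered here, and "the series" means these few. Any claim that something is new, unique, unknown or untested is made for them only; others in the source may bear on it.

Compound 1 `CN(C)c1ccc(/C=C2/SC(=Nc3ccccc3)NC2=O)cc1`: 0.1 ug/mL
Compound 2 `CCN(CC)c1ccc(/C=C2/SC(Nc3ccccc3)=NC2=O)cc1`: 0.1 ug/mL

In a physicochemical assay (Homo sapiens) for solubility, with a stated time of 18 h, at pH 7.4 (a lower number here means a less soluble compound, a higher number a more soluble compound), compound 1 gives 0.1 ug/mL. In this assay compound 2 gives 0.1 ug/mL. Compound 1 stands level with compound 2 at the digits shown; the two values lie within the scatter, so neither can be called the more soluble. Compound 3 `CN(C)c1ccc(/C=C2/SC(=Nc3ccc(O)cc3)NC2=O)cc1` has not yet been measured. It differs from compound 1 by hydroxy in place of hydrogen on an aromatic carbon. Within the data shown here, no measured pair shows this change, so the expected step of a 2.0-fold higher number from compound 1 to compound 3 (0.30 log units; within the scatter) is a small rise at most, not clearly beyond the scatter. Compound 3 is thus estimated at 0.2 ug/mL, between 0.1 ug/mL and 0.6 ug/mL.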

Compound 3, solubility: 0.01 ug/mL
The estimate for compound 3 lay 20-fold (1.30 log units) above the measured number, and the stated range ends above it.
By their numbers in this assay, from the lowest: compound 3; then compounds 1 and 2 (each within the scatter of the next).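

In this assay, hydroxy in place of hydrogen on an aromatic carbon, para to a large group, gives a 10-fold lower number from compound 1 to compound 3 (1.00 log units; beyond the scatter). Among these compounds, this is the first sign that the read-out responds to a change at this position, and a single added oxygen is enough to move it downward. Nothing measured here explains the drop.

Going by these compounds, whether an amine or a carboxylic acid at this same place would also lower the number remains open. So does whether hydroxy would act the same way on the diethylamino-bearing compound 2.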